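The compounds below may be only part of what the source reports. "The series", "measured", "known", "first", "only" and "open" are said of these compounds alone.

Values in a functional assay on RCC4 cells (Homo sapiens) for inhibition, read by XTT assay, with a stated time of 4 days; a higher number here means a weaker inhibitor, a lower number a stronger inhibitor:
Compound 1 `Cc1cccc(Nc2nc(-c3ccnc(-c4cnn(C)c4)c3)cs2)c1`: 5200 nM; 5250 nM (2 entries)
Compound 2 `Cc1cccc(Nc2nc(-c3ccnc(-c4cccc5[nH]ccc45)c3)cs2)c1`: 3100 nM; 3160 nM (2 entries)
Compound 3 `C#Cc1cc(-c2csc(Nc3cccc(C)c3)n2)ccn1`: 18200 nM

Repeat entries agree closely for the first two compounds, as seen in the several entries of compound 1 in this assay, 5200 nM; 5250 nM (2 entries) and (the several entries of compound 2 in this assay, 3100 nM; 3160 nM (2 entries)). For the measured compounds named here, compound 3 has only one numeric value, 18200 nM, the highest number of the three, and two further entries give no single number. It therefore stands on thinner evidence than the other two.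

Compound 4 `Cc1cccc(Nc2nc(-c3ccnc(C)c3)cs2)c1` has methyl in place of ethynyl on an aromatic carbon, next to the ring nitrogen (methyl in place of ethynyl on an aromatic carbon). Going by the values given here, no single-place step has been measured, so the expectation rests only on the spread of the three values. A modest move towards a lower number in this assay is expected, and no change beyond the scatter remains plausible. The expected step is a 1.7-fold lower number from compound 3 to compound 4 (0.22 log units; within the scatter). For compound 4 the estimated value is 11000 nM, with an expected range from 3500 nM to 32000 nM.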

Compound 4, half-maximal inhibitory concentration: 28800 nM
Estimate against measurement, compound 4: 2.6-fold (0.42 log units) below; low and high end bracket the measured number.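

In this assay, the only single-place step shown is methyl in place of ethynyl on an aromatic carbon next to the ring nitrogen, and it gives a 1.6-fold higher number from compound 3 to compound 4 (0.20 log units; within the scatter). At this place, therefore, the loss of the triple bond and of one carbon does not separate the two groups in this read-out. This reading rests on a single number for each of the two compounds, whereas repeat entries agree closely elsewhere in the series: the several entries of compound 1 in this assay, 5200 nM; 5250 nM (2 entries)

For the compounds shown here, the larger groups at this place in compound 1 (printed value 5200 nM; 5250 nM (2 entries)) and compound 2 (printed value 3100 nM; 3160 nM (2 entries)) have no step set against compound 4, so their size of effect remains unread. On these data alone, whether an amine or a carboxylic acid at this carbon would move the number beyond the scatter remains open.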